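Methyl added on a saturated chain carbon: near or far

A few compounds are considered here, and "the series" means these few. Any claim that something is new, unique, unknown or untested is made for them only; others in the source may bear on it.

Three compounds share one core and differ only in the group on the aromatic nitrogen. Compound 1 `CCCCCn1ccc2cc(/C(C)=C/C(=O)Nc3ccccc3OCCCC(=O)O)ccc21` gives 23 nM in an assay on Prostate gland for inhibition of steroid 5-alpha-reductase (Rattus norvegicus); a lower number here means a stronger inhibitor, a higher number a weaker inhibitor. Compound 2 `CCCCC(C)n1ccc2cc(/C(C)=C/C(=O)Nc3ccccc3OCCCC(=O)O)ccc21` gives 6 nM, and compound 3 `CCC(c1ccccc1)n1ccc2cc(/C(C)=C/C(=O)Nc3ccccc3OCCCC(=O)O)ccc21` gives 19 nM. The change methyl in place of hydrogen on a saturated chain carbon bound to an aromatic nitrogen and a saturated chain carbon made a 3.8-fold lower number from compound 1 to compound 2 (0.58 log units; beyond the scatter). The two cores differ by 1-phenylpropyl in place of pentyl on an aromatic nitrogen, with a 1.2-fold lower number from compound 1 to compound 3 (0.08 log units; within the scatter). Compound 4 `CCCC(c1ccccc1)n1ccc2cc(/C(C)=C/C(=O)Nc3ccccc3OCCCC(=O)O)ccc21` differs from compound 3 by methyl in place of hydrogen on a saturated chain carbon, three bonds along the chain from an aromatic carbon and an aromatic nitrogen, the same kind of change as before but not the same: earlier the carbon was bound to an aromatic nitrogen and a saturated chain carbon, here it lies three bonds along the chain from an aromatic carbon and an aromatic nitrogen. A smaller step is expected, a 1.4-fold lower number from compound 3 to compound 4 (0.13 log units; within the scatter), since the added methyl sits farther out. Compound 4 is estimated at 14 nM, between 5 nM and 40 nM.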

Compound 4, half-maximal inhibitory concentration: 9.1 nM
Compound 4: the middle estimate sits 1.5-fold (0.19 log units) above what was measured, within the range that was stated.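

In this assay, adding the methyl gives a 2.1-fold lower number from compound 3 to compound 4 (0.32 log units; beyond the scatter), and this step agrees with the earlier one: the same change on two cores in this assay, a 3.8-fold lower number (0.58 log units; beyond the scatter) from compound 1 to compound 2 and a 2.1-fold lower number (0.32 log units; beyond the scatter) from compound 3 to compound 4, 1.8-fold (0.26 log units) apart, within the scatter of two such steps. On these two cores, then, the change carried over in direction, and any difference in its size cannot be told from scatter, but two pairs give no rule for other cores. The 1-phenylbutyl group gives a 2.5-fold lower number from compound 1 to compound 4 (0.40 log units; beyond the scatter) against pentyl, while against 1-methylpentyl it gives a 1.5-fold higher number from compound 2 to compound 4 (0.18 log units; within the scatter), a step too small to separate the two groups.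

From the compounds shown here alone, it remains open whether the methyl step would hold on a core with a benzyl or cyclohexyl group on the aromatic nitrogen. An amine at the end of the chain is equally untested here.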